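The compounds below may be only part of what the source reports. "The series", "measured", "known", "first", "only" and "open" are said of these compounds alone.

Working notes on the series in a functional assay (plasma) with Oryctolagus cuniculus as the target; on this read-out lower numbers stand for stronger inhibition and higher numbers for weaker inhibition. Compound 1 `CC(C)c1ccc2c(CCC/C=N\NC(=O)Nc3ccccc3)cc(C(=O)O)c-2cc1` gives only a limit there, > 1000000 nM. Compound 2 `CC(C)c1ccc2c(CCCCS(=O)(=O)Nc3ccc(Cl)cc3)cc(C(=O)O)c-2cc1` likewise gives only a limit, > 1000000 nM. Both values sit at the limit of > 1000000 nM in this assay, at which 2 of the 2 values shown sit, so compound 2 stands at the edge of this assay, with no number beneath it and nothing to rank it against. Compound 3 `CC(C)c1ccc2c(CCCCS(=O)(=O)Nc3ccc(Cl)cc3)cc(S(=O)(=O)O)c-2cc1` differs from compound 2 by sulfo in place of carboxy on an aromatic carbon. Within the data shown here, no measured step in this assay covers such a change. The expected step, a number no higher from compound 2 to compound 3 (the limit leaves the size open), amounts to none beyond the scatter, with a limit the probable outcome. The estimate for compound 3 in this assay is 1000000 nM, within 300000 nM to 3000000 nM.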

Compound 3, half-maximal inhibitory concentration: > 1000000 nM
Compound 3: no number, only a limit; the forecaster's own chance of this, stated with the estimate: 85%; the middle value lies on the limit itself.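

No step can be read from compound 2 to compound 3, since each gives only a limit: the limit of > 1000000 nM in this assay, at which 3 of the 3 values shown sit.

Whether sulfo in place of carboxy on an aromatic carbon changes the read-out at all stays open, as does any ranking of the compounds shown.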